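Swapping a ring for a branched chain at the aryl tail

A few compounds are considered here, and "the series" means these few. Any claim that something is new, unique, unknown or untested is made for them only; others in the source may bear on it.

Measured compounds in an assay on HEK293 cells for displacement of a labelled ligand from NPC1-like intracellular cholesterol transporter 1 (Homo sapiens); on this read-out higher numbers stand for weaker inhibition and lower numbers for stronger inhibition:
- compound 1 `CC(C)(C)OC(=O)NCCNC(=O)CN1CN(c2ccccc2)C2(CCN(C(=O)c3ccc(C(C)(C)C)cc3)CC2)C1=O` gives 10900 nM
- compound 2 `CC1(C)CC(OC(=O)CN2CN(c3ccccc3)C3(CCN(C(=O)c4ccc(C(C)(C)C)cc4)CC3)C2=O)CC(C)(C)N1` gives 1300 nM
- compound 3 `CS(=O)(=O)NCCCNC(=O)CN1CN(c2ccccc2)C2(CCN(C(=O)c3ccc(C4CCCCC4)cc3)CC2)C1=O` gives 3800 nM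

Among these three, compound 3 stands second highest: compound 1 sits above it and compound 2 below it, both separated by more than the usual scatter. Among the measured compounds shown here, the only single-point step measured is an 8.4-fold lower number from compound 1 to compound 2 (0.92 log units; beyond the scatter), which concerns the amide-bearing side chain and not the aryl tail.

Compound 4 `CC(C)(C)c1ccc(C(=O)N2CCC3(CC2)C(=O)N(CC(=O)NCCCNS(C)(=O)=O)CN3c2ccccc2)cc1` differs from compound 3 at that tail: tert-butyl in place of cyclohexyl on an aromatic carbon. Compounds 1 and 2 already carry tert-butyl there. Their side chains differ from that of compound 3. Their values show only that tert-butyl is compatible with numbers on either side of that of compound 3, which gives 3800 nM. For the measured compounds named here, no measured step isolates the cyclohexyl to tert-butyl change, so the expected step of a 1.1-fold higher number from compound 3 to compound 4 (0.02 log units; within the scatter) is within the scatter, in no particular direction. Compound 4 is therefore estimated at 4000 nM, in a range from 1500 nM to 11000 nM.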

Compound 4, half-maximal inhibitory concentration: 10400 nM
Compound 4: middle estimate off by 2.6-fold (0.41 log units), on the low side; low and high end bracket the measured number.
By their numbers in this assay, from the lowest: compound 2; then compound 3; then compounds 4 and 1 (each within the scatter of the next).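

With the side chain held fixed, putting tert-butyl in place of cyclohexyl on the aromatic carbon gives a 2.7-fold higher number from compound 3 to compound 4 (0.44 log units; beyond the scatter) in this assay, so this position does respond to the change, and the 4-cyclohexylphenyl tail gives the stronger inhibition of this pair. With tert-butyl held fixed, the side chain also matters: the (3-(methanesulfonamido)propyl)amino group gives an 8.0-fold higher number from compound 2 to compound 4 (0.90 log units; beyond the scatter) when it replaces the (2,2,6,6-tetramethylpiperidin-4-yl)oxy group, while the step of a 1.0-fold lower number from compound 1 to compound 4 (0.02 log units; within the scatter) stays within the scatter. No available evidence explains the difference between the two tails.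

Going by these compounds, the tail comparison rests on a single pair, so it remains open whether cyclohexyl gives the same advantage with other side chains. On these data alone, how a phenyl ring, a methyl group or a longer straight alkyl chain would behave on this aromatic carbon also remains open.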